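Swapping chloro for methoxy on the pyrimidine-borne phenyl ring

The source may hold more compounds than are shown below. What is called first, only, known or untested is meant among the compounds shown, and "the series" means these compounds.

Measured compounds:
compound 1, `COc1ccc(-c2nc(SCC(=O)c3sc(-c4ccccc4)nc3C)nc(N)c2C#N)cc1`, 68.8%
compound 2, `Cc1nc(-c2ccc(Cl)cc2)sc1C(=O)CSc1nc(N)c(C#N)c(-c2ccc(Cl)cc2)n1`, 46.1%

In a functional assay on U-87MG ATCC cells for antiproliferative activity against U-87 MG (Homo sapiens), read by MTT assay, with a stated time of 48 h, tested at 5 uM (on this read-out higher numbers stand for a weaker effect at the one concentration tested and lower numbers for a stronger effect), compound 2 gives 46.1%, the lower of the two numbers, and compound 1 gives 68.8%, a number higher by a gap beyond the scatter. Going by the values given here, the two differ in more than one place, so no single step between them is known. Compound 3, `COc1ccc(-c2nc(SCC(=O)c3sc(-c4ccc(Cl)cc4)nc3C)nc(N)c2C#N)cc1`, is not yet measured. It differs from compound 2 in one place: methoxy in place of chloro on an aromatic carbon.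

Compound 1 carries the same methoxy-bearing ring and gives 68.8%, which is the only hint available. On that hint, the step of a number 11.9 percentage points higher from compound 2 to compound 3 (beyond the scatter) is expected to raise the number moderately, though it may stay within the scatter. The value of compound 3 in this assay is estimated at 58%, within a range from 42% to 74%.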

Compound 3, a percentage reported as activity, at one concentration (the size of the read-out at that concentration, not a potency): 69.7%
Compound 3: middle estimate off by 11.7 percentage points, on the low side; low and high end bracket the measured number.
By their numbers in this assay, from the lowest: compound 2; then compounds 1 and 3 (each within the scatter of the next).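

In this assay, going by these compounds alone, the change from 4-chlorophenyl to 4-methoxyphenyl gives a number 23.6 percentage points higher from compound 2 to compound 3 (beyond the scatter), the first single-place reading at this position, and it shows that the position responds to this swap, with methoxy giving the weaker effect at the one concentration tested. Chloro in place of hydrogen on an aromatic carbon elsewhere in the molecule, with the methoxy kept, gives a number 0.9 percentage points higher from compound 1 to compound 3 (within the scatter), so in this methoxy-bearing pair that added chloro shows no change beyond the scatter. No measurement bears on why the swap has this effect.

The compounds shown leave open how a hydroxyl or an amine would read at this aromatic carbon. They also leave open whether the chloro in place of hydrogen step would read the same with chloro rather than methoxy on the 4-substituted ring.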